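A few compounds are considered here, and "the series" means these few. Any claim that something is new, unique, unknown or untested is made for them only; others in the source may bear on it.

Working notes on the ester side chain over the shared core. In an ADME assay on HepG2 2.2.15 cells (Homo sapiens) for cytotoxicity (on this read-out lower numbers stand for higher toxicity in this test and higher numbers for lower toxicity in this test), compound 1 (`CC(=O)OCCc1c(-c2ccccc2Cl)c2cc(Cl)ccc2[nH]c1=O`) gives 27000 nM and compound 2 (`N#CCC(=O)OCCc1c(-c2ccccc2Cl)c2cc(Cl)ccc2[nH]c1=O`) gives 100000 nM, the higher of the two numbers. Next is compound 3 (`COCC(=O)OCCc1c(-c2ccccc2Cl)c2cc(Cl)ccc2[nH]c1=O`), with methoxy in place of cyano on a saturated chain carbon bound to a carbonyl carbon. Within the data shown here, the only measured step bearing on this is the modest 3.7-fold higher number from compound 1 to compound 2 (0.57 log units; beyond the scatter), which introduced cyano; no methoxy data exist yet. A modest drop in this assay is therefore expected, and the estimated step is a 2.0-fold lower number from compound 2 to compound 3 (0.30 log units; within the scatter). For compound 3 the estimate is 50000 nM, with an expected range of 20000 nM to 100000 nM.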

Compound 3, half-maximal cytotoxic concentration: 74000 nM
Compound 3: the middle estimate sits 1.5-fold (0.17 log units) below what was measured; measured number inside the range.
By their numbers in this assay, from the lowest: compound 1; then compounds 3 and 2 (each within the scatter of the next).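

Methoxy and cyano on a saturated chain carbon bound to a carbonyl carbon cannot be told apart in this assay (a 1.4-fold lower number from compound 2 to compound 3 (0.13 log units; within the scatter)). Methoxy in place of hydrogen at this place also gives a step beyond the scatter (a 2.7-fold higher number from compound 1 to compound 3 (0.44 log units; beyond the scatter)), so the higher number is not tied to cyano alone. No evidence bears on the reason for this.

From the compounds shown here alone, whether an amine, a carboxylic acid or a longer chain at this place would read like methoxy and cyano or like hydrogen stays open.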